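The source may report more compounds than this note shows. Statements on the series, on what has been measured and on what is new or still open speak of the compounds shown alone.

Measured in a functional assay on Jurkat cells (Homo sapiens) for antiproliferative activity, read by MTT assay, with a stated time of 6 days; on this read-out higher numbers stand for weaker inhibition and lower numbers for stronger inhibition:
- compound 1 `O=C1C=C[C@@H](OCc2ccccc2)[C@@H]([C@@H](COC(=O)/C=C/c2ccccc2)OCc2ccccc2)O1`: 4960 nM
- compound 2 `O=C1C=C[C@@H](OCc2ccccc2)[C@@H]([C@@H](COC(=O)/C=C/c2ccc(F)cc2)OCc2ccccc2)O1`: 4160 nM
- compound 3 `O=C1C=C[C@@H](OCc2ccccc2)[C@@H]([C@@H](COC(=O)/C=C/c2ccc([N+](=O)[O-])cc2)OCc2ccccc2)O1`: 5710 nM

Not yet measured: compound 4 `O=C1C=C[C@@H](OCc2ccccc2)[C@@H]([C@@H](CO)OCc2ccccc2)O1`.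

Compound 2, at 4160 nM, stands level with the other two compounds. Both a 1.2-fold lower number from compound 1 to compound 2 (0.08 log units; within the scatter) and a 1.4-fold higher number from compound 2 to compound 3 (0.14 log units; within the scatter) lie within the scatter, so the three values do not separate.

The step to follow is hydrogen in place of (2-(4-fluorophenyl)ethenyl)carbonyl on an oxygen on a saturated carbon. In words, this is hydrogen in place of (2-(4-fluorophenyl)ethenyl)carbonyl on an oxygen on a saturated carbon, or ((2-(4-fluorophenyl)ethenyl)carbonyl)oxy to hydroxy.

The nearest evidence is a 1.2-fold lower number from compound 1 to compound 2 (0.08 log units; within the scatter), a 1.2-fold higher number from compound 1 to compound 3 (0.06 log units; within the scatter) and a 1.4-fold higher number from compound 2 to compound 3 (0.14 log units; within the scatter). All three are small and within the scatter, but each only exchanges a group on an aromatic carbon. For the measured compounds named here, none removes the whole (2-(4-fluorophenyl)ethenyl)carbonyl group, and no measured compound lacks it. These steps therefore bear on the new change only weakly, and they give no direction for it.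

In this assay, no step beyond the scatter is expected as the central guess, though with wide uncertainty. The expected step is a 1.4-fold higher number from compound 2 to compound 4 (0.16 log units; within the scatter).

For compound 4 the estimated value is 6000 nM, with an expected range from 1500 nM to 25000 nM.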

Compound 4, half-maximal inhibitory concentration: 12300 nM
The estimate for compound 4 lay 2.1-fold (0.31 log units) below the measured number, and the stated range covers the measured number.
By their numbers in this assay, from the lowest: compounds 2, 1 and 3 (each within the scatter of the next); then compound 4.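

In this assay, taking the whole acyl group off the oxygen on the saturated carbon moves the number beyond the scatter, unlike the exchanges of fluoro and nitro on the aromatic carbon: a 3.0-fold higher number from compound 2 to compound 4 (0.47 log units; beyond the scatter), and a 2.5-fold higher number from compound 1 to compound 4 (0.39 log units; beyond the scatter). Both steps are modest and point the same way, so at this position the presence of the (2-phenylethenyl)carbonyl type of group counts for more than the substituent on its aromatic ring, while the hydroxy compound 4 still gives a measured number of 12300 nM. No measurement shown here accounts for this difference.

The compounds shown leave open which part of the departing group carries the difference, the ester carbonyl, the ethenyl link or the aromatic ring, and a small acetyl ester or a saturated 3-phenylpropanoyl ester on the same oxygen would separate these parts. They also leave open whether the oxygen link itself matters, which an amide nitrogen in its place or a benzyl ether on the same oxygen would address.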